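The source may hold more compounds than are shown below. What is called first, only, known or untested is meant among the compounds shown, and "the series" means these compounds.

Measured in a functional assay on MCF7 cells (Homo sapiens) for antiproliferative activity, read by MTT assay, with stated times of 24 h and 72 h; on this read-out higher numbers stand for weaker inhibition and lower numbers for stronger inhibition:
- compound 1 `COc1cc(N2C(=O)[C@@H](Oc3ccccc3)[C@H]2c2ccc(SC)cc2)cc(OC)c1OC`: 7700 nM
- compound 2 `COc1cc(N2C(=O)[C@@H](Oc3ccccc3)[C@H]2c2cc(N)c(OC)c(O)c2)cc(OC)c1OC`: 8800 nM

Among the compounds with values here, compound 2 stands level with the only other measured compound. Compound 3 `COc1cc(N)c([C@@H]2[C@H](Oc3ccccc3)C(=O)N2c2cc(OC)c(OC)c(OC)c2)cc1O` has the same atoms as compound 2, joined differently: a group of 10 heavy atoms (7 carbon, 1 nitrogen, 2 oxygen; one six-membered aromatic ring of carbon only) in place of a group of 10 heavy atoms (7 carbon, 1 nitrogen, 2 oxygen; one six-membered aromatic ring of carbon only), on a saturated ring carbon. Within the data shown here, the one measured step, a 1.1-fold higher number from compound 1 to compound 2 (0.06 log units; within the scatter), exchanged the group at this same place and stayed within the scatter. Among the measured compounds shown here, no measured step tests a rearrangement of this kind. No step beyond the scatter is therefore expected in this assay. The expected change is a 1.0-fold higher number from compound 2 to compound 3 (0.01 log units; within the scatter). Compound 3 is estimated at 9000 nM, with an expected range of 2500 nM to 30000 nM.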

Compound 3, half-maximal inhibitory concentration: 20000 nM
Compound 3: the middle estimate sits 2.2-fold (0.35 log units) below what was measured, within the range that was stated.
By their numbers in this assay, from the lowest: compounds 1 and 2 (each within the scatter of the next); then compound 3.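

In this assay, the same atoms joined differently on the saturated ring carbon give a 2.3-fold higher number from compound 2 to compound 3 (0.36 log units; beyond the scatter), so the arrangement within this group can shift the read-out even with composition and donor and acceptor counts unchanged. The exchange of a different group at this place also gives a 2.6-fold higher number from compound 1 to compound 3 (0.41 log units; beyond the scatter), so this position is not indifferent to every change. Nothing available explains the shift.

Which part of the rearranged group carries the step remains open. So does whether a carboxylic acid or a longer chain in place of the amine would move the number further.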